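Swapping a Bromophenyl for a Nitrophenyl: Toxicity Outlook

The compounds below may be only part of what the source reports. "The series", "measured", "known", "first", "only" and "open" are said of these compounds alone.

Compound 1 `COC(=O)c1cc(-c2cccc(NC(=O)c3ccc(/C=C/C(=O)c4ccccc4Br)cc3)c2)on1` was examined in an ADME assay on Vero cells (Chlorocebus sabaeus) for cytotoxicity, read by MTT assay, with a stated time of 72 h (on this read-out lower numbers stand for higher toxicity in this test and higher numbers for lower toxicity in this test), where compound 1 gives > 40 ug/mL, which is a limit of the test rather than a number. Compound 3 `COC(=O)c1cc(-c2ccc(NC(=O)c3ccc(/C=C/C(=O)c4ccc(Cl)cc4)cc3)cc2)on1` shares the same core and arm; in this assay compound 3 gives > 80 ug/mL, also a limit. Compound 2 `CCOC(=O)c1cc(-c2cccc(NC(=O)c3cccc(C(F)(F)F)c3)c2)on1` has a shorter amide arm, and in this assay compound 2 gives "not determined" (no result reported). Compound 1 therefore stands at one of two limits among the three entries (the limit of > 40 ug/mL in this assay, at which 1 of the 3 values shown sits, (the limit of > 80 ug/mL in this assay, at which 1 of the 3 values shown sits)), and no single number exists to compare against.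

Compound 4 `COC(=O)c1cc(-c2cccc(NC(=O)c3ccc(/C=C/C(=O)c4ccc([N+](=O)[O-])cc4)cc3)c2)on1` differs from compound 1 in one place: 4-nitrophenyl in place of 2-bromophenyl on a carbonyl carbon. Among the measured compounds shown here, no pair of measured compounds shows what such a change does in this assay, so the expected step is a step that the limit leaves unreadable from compound 1 to compound 4, none beyond the scatter, because compound 1 gives > 40 ug/mL and no numbered value pulls elsewhere. Compound 4 is expected to give 60 ug/mL, within 25 ug/mL to 150 ug/mL.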

Compound 4, half-maximal cytotoxic concentration: > 20 ug/mL
Compound 4: only a limit was reported (the forecaster's own chance of this, stated with the estimate: 70%); the middle value is on the limit's open side.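

Among the compounds shown here, compound 1 and compound 4 each carry only a limit of the test, so no step between them can be read. On these data alone, what 4-nitrophenyl in place of 2-bromophenyl does in this assay stays open, as does where the true value of either compound lies.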